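Adding a methyl to the phenol of compound 1

The source may hold more compounds than are shown below. What is called first, only, known or untested is meant among the compounds shown, and "the series" means these compounds.

Measured in a functional assay on L5178Y cells (Mus musculus) for inhibition, read by MTT assay, with a stated time of 24 h; a lower number here means a stronger inhibitor, a higher number a weaker inhibitor:
compound 1 `COc1cc(O)c2c(c1)O[C@H](c1ccc(O)cc1)C/C2=N\N`: >= 11300 nM (a limit)
compound 2 `COc1cc(O)c2c(c1)O[C@H](c1ccc(O)cc1)C/C2=N\NC(=O)c1cccs1`: 9400 nM

Compound 1 has no exact number, since >= 11300 nM is a limit of this assay. Compound 1 therefore stands at the limit of >= 11300 nM in this assay, at which 1 of the 2 values shown sits. From the compounds shown here alone, it is a weak inhibitor here, but how weak remains open.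

Compound 3 `COc1ccc([C@@H]2C/C(=N\N)c3c(O)cc(OC)cc3O2)cc1` keeps the core of compound 1 and carries one change: methyl in place of hydrogen on an oxygen on an aromatic ring. In words, a hydroxy becomes a methoxy, with methyl in place of hydrogen on an oxygen on an aromatic ring.

Within the data shown here, only one measured step is available, an at least 1.2-fold lower number from compound 1 to compound 2 (0.07 log units; that floor lies within the scatter). It places (thiophen-2-yl)carbonyl on an amine nitrogen, a different place from the oxygen changed in compound 3, so it offers only a loose guide. Going by that small step to compound 2, no shift beyond the scatter is expected in this assay, and no direction can be favoured.

The estimated step is a step that the limit leaves unreadable from compound 1 to compound 3. Compound 3 is expected at 12000 nM, with an estimated range from 5000 nM to 30000 nM.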

Compound 3, half-maximal inhibitory concentration: >= 11300 nM
Compound 3: no number, only a limit; the forecaster's own chance of this, stated with the estimate: 40%; the middle value does not contradict the limit.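

In this assay, no step can be read from compound 1 to compound 3, since each gives only a limit and not an exact number: the limit of >= 11300 nM in this assay, at which 2 of the 3 values shown sit. The compounds shown leave open how weak compound 1 and compound 3 truly are, and whether changing hydroxy to methoxy shifts inhibition at all.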